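The compounds below may be only part of what the source reports. "The series", "measured", "known", "first", "only" and "open" are said of these compounds alone.

Measured compounds:
compound 1 `COc1ccc2[nH]c(-c3ccccc3)c(C=C(C#N)C#N)c2c1` gives 3600 nM in a functional assay on SW-620 cells (Homo sapiens) for inhibition, read by sulforhodamine B assay, with a stated time of 48 h; a lower number here means a stronger inhibitor of growth, a higher number a weaker inhibitor of growth
compound 2 `CCOC(=O)C(=Cc1c(-c2ccccc2)[nH]c2ccccc12)C(=O)OCC` gives 5600 nM
compound 3 `CC(=O)/C(=C\c1c(-c2ccccc2)[nH]c2ccccc12)S(=O)(=O)c1ccccc1` gives 778 nM

Compound 3 carries the lowest of the three numbers in this assay. The nearest of the other two is compound 1, whose value sits well beyond the usual scatter above that of compound 3, and the furthest is compound 2, whose value lies further still. Compound 3 is therefore the strongest inhibitor of growth among the three measured compounds, and all three share the same core, differing only in the chain that hangs from it.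

The next compound, compound 4 `N#C/C(=C\c1c(-c2ccccc2)[nH]c2ccccc12)S(=O)(=O)c1ccccc1`, is not yet measured. It differs from compound 3 in one place: cyano in place of acetyl on a double-bonded chain carbon bound to a double-bonded chain carbon and a sulfonyl sulfur. The sulfonyl group is kept, and only the partner on the same chain carbon changes.

Among the measured compounds shown here, no pair of measured compounds differs in exactly this way, so there is no measured step to lean on. Given the value of compound 3 at 778 nM and the modest size of the change, compound 4 is expected to land close to compound 3, with a step of a 1.1-fold lower number from compound 3 to compound 4 (0.05 log units; within the scatter) that is not expected to exceed the scatter. Compound 4 is estimated at 700 nM, within a range from 250 nM to 2000 nM.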

Compound 4, concentration for 50% growth inhibition: 570 nM
Compound 4: the middle estimate sits 1.2-fold (0.09 log units) above what was measured, within the range that was stated.
By their numbers in this assay, from the lowest: compounds 4 and 3 (each within the scatter of the next); then compounds 1 and 2 (each within the scatter of the next).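

In this assay, cyano in place of acetyl on a double-bonded chain carbon bound to a double-bonded chain carbon and a sulfonyl sulfur gives a 1.4-fold lower number from compound 3 to compound 4 (0.14 log units; within the scatter) and so leaves the reading within the scatter. This is the first pair shown that differs in one place only, and it shows that, with the sulfonyl group kept, the growth inhibition of compound 3 does not depend on the acetyl group, since a cyano group at the same carbon serves as well in this assay. Nothing measured here bears on why the two groups read alike.

Among the compounds shown here, whether a carboxylic acid, an amide or a longer chain ketone on this carbon would also read alike remains open, so the single swap cannot show how broad this tolerance is. Equally open, on these data alone, is what the phenyl ring on the sulfonyl group contributes, as a methyl group or an amine on the sulfur would be needed to test it with the cyano partner held in place.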